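A few compounds are considered here, and "the series" means these few. Any claim that something is new, unique, unknown or untested is made for them only; others in the source may bear on it.

The measured compounds:
Compound 1, `O=c1cc(-c2ccccc2)oc2cccc(OCCCCN3CCC(O)CC3)c12`, gives 58 nM in an assay on isolated protein (Cavia porcellus) with Sigma non-opioid intracellular receptor 1 (Homo sapiens) as the target, read by radioligand binding; a lower number here means a stronger inhibitor, a higher number a weaker inhibitor.
Compound 2, `O=c1cc(-c2ccccc2)oc2cccc(OCCCCCCCN3CCC(O)CC3)c12`, gives 36 nM in this assay.
Compound 3, `O=c1cc(-c2ccccc2Cl)oc2ccc(OCCCCCCN3CCC(O)CC3)cc12`, gives 47 nM in this assay.

Compound 3 holds the second highest of these three numbers; compound 1 lies nearest and compound 2 furthest, and both gaps are within the scatter, so the three cannot be told apart. Compound 4, `O=c1cc(-c2ccncc2)oc2ccc(OCCCCCCN3CCC(O)CC3)cc12`, differs from compound 3 in one place: pyridin-4-yl in place of 2-chlorophenyl on an aromatic carbon. Among the compounds with values here, the only measured step, a 1.6-fold lower number from compound 1 to compound 2 (0.21 log units; within the scatter), concerns the chain and not the aryl ring, so no measured step bears on this change, and there is no basis for expecting a shift beyond the scatter. The expected step is a 1.9-fold higher number from compound 3 to compound 4 (0.28 log units; within the scatter). For compound 4 in this assay the estimate is 90 nM, within 30 nM to 300 nM.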

Compound 4, half-maximal inhibitory concentration: 159 nM
Compound 4: middle estimate off by 1.8-fold (0.25 log units), on the low side; measured number inside the range.
By their numbers in this assay, from the lowest: compounds 2, 3 and 1 (each within the scatter of the next); then compound 4.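

In this assay, the group on this aromatic carbon, next to the ring oxygen, proves to matter: pyridin-4-yl in place of 2-chlorophenyl gives a 3.4-fold higher number from compound 3 to compound 4 (0.53 log units; beyond the scatter) and is the only step shown that lies beyond the scatter. The change removes the chlorine and brings in a ring nitrogen together, so this step cannot separate the two. Nothing available accounts for the shift.

Still open, as far as these compounds go, is what a 2-methylphenyl or pyridin-3-yl group would give at this carbon. From the compounds shown here alone, whether the same change would have a similar effect on the core of compound 1 is also open.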